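This account rests on a few compounds, and the source may have more. Where it says the series, first, only, none or still open, it means among the compounds named here.

Compound 1 `COCC1=C2/C(=C\[C@@]3(C)CC[C@](O)(O3)[C@@](C)(O)C[C@@H]2O)OC1=O` is the starting point in a functional assay on HepG2 cells (Homo sapiens) for cytotoxicity; on this read-out higher numbers stand for weaker inhibition and lower numbers for stronger inhibition. In this assay compound 1 gives > 5 ug/mL, which is a limit of the assay and not a number. Compound 2 `C/C=C(\C)C(=O)O[C@H]1C[C@](C)(O)[C@]2(O)CC[C@](C)(/C=C3/OC(=O)C(COC)=C31)O2` carries (1-methylprop-1-en-1-yl)carbonyl in place of hydrogen on an oxygen on a saturated carbon, and in this assay compound 2 gives > 5 ug/mL, likewise a limit. Compound 3 `COCC1=C2[C@@H](OC(C)=O)C[C@@]3(C)O[C@@]2(OC1=O)[C@H](O)[C@@]1(C)CC[C@]3(O)O1` gives > 5 ug/mL in this assay, also a limit. The step that the two limits leave unreadable from compound 1 to compound 2 therefore cannot be read in size, and the whole of the evidence is the limit of > 5 ug/mL in this assay, at which 3 of the 3 values shown sit. Compound 4 `CC(=O)OCC1=C2/C(=C\[C@@]3(C)CC[C@](O)(O3)[C@@](C)(O)C[C@@H]2O)OC1=O` is not yet measured; it differs from compound 1 in one place: acetyl in place of methyl on an oxygen on a saturated carbon. Going by the values given here, because the limit of > 5 ug/mL in this assay, at which 3 of the 3 values shown sit, holds every value shown on one limit, no measured step bears on this change with a readable size, and no movement beyond the scatter is expected. The step that the limit leaves unreadable from compound 1 to compound 4 is estimated to be small. Compound 4 is expected to give 10 ug/mL in this assay, within 4 ug/mL to 30 ug/mL.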

Compound 4, half-maximal inhibitory concentration: > 5 ug/mL
Compound 4 gave a limit, no number (the forecaster's own chance of this, stated with the estimate: 85%); the middle value lies beyond the limit too.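

Compound 1 and compound 4 both stand at a limit and not a number in this assay, so no size can be read for the change from methoxymethyl to acetoxymethyl. The compounds shown leave open how strongly any of them inhibits, since all rest on one limit: the limit of > 5 ug/mL in this assay, at which 4 of the 4 values shown sit.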